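Cyclohexyl for phenyl on the ring nitrogen

The source may hold more compounds than are shown below. What is called first, only, known or untested is meant among the compounds shown, and "the series" means these compounds.

Measured so far:
compound 1 `COc1ccc(-n2sc(=O)n(-c3ccc(OC)cc3)c2=O)cc1`: < 2000 nM
compound 2 `COc1ccc(-n2sc(=O)n(-c3ccccc3)c2=O)cc1`: < 2000 nM

In an ADME assay, in phosphate buffer, with a stated time of 30 min, tested at 1 mM, at a dose of 1 mM (on this read-out lower numbers stand for lower exposure and higher numbers for higher exposure at the dose given), compound 1 gives < 2000 nM, which is a limit of the assay and not a number. Compound 2 gives < 2000 nM, likewise a limit. The step that the two limits leave unreadable from compound 1 to compound 2 is therefore not readable in size, and both results sit at the limit of < 2000 nM in this assay, at which 2 of the 2 values shown sit.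

Compound 3 `COc1ccc(-n2sc(=O)n(C3CCCCC3)c2=O)cc1` is the next member: cyclohexyl in place of phenyl on an aromatic nitrogen. Among the compounds with values here, the only measured step, the one from compound 1 to compound 2, is unreadable and bears on this change only in showing that the series has so far stayed at the limit. Within the data shown here, no measured step gives a direction or size for the step to compound 3.

On that basis compound 3 is expected to remain near or under the limit, with an estimate of 1000 nM, range 250 nM to 3000 nM. The expected step is a step that the limit leaves unreadable from compound 2 to compound 3, none beyond the scatter.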

Compound 3, maximal plasma concentration: < 2000 nM
Compound 3 was reported as a limit; the forecaster's own chance of this, stated with the estimate: 70%; the middle value lies beyond the limit too.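

No size can be read for the step from compound 2 to compound 3, nor for the earlier step from compound 1 to compound 2, as all three compounds stand at one assay limit: the limit of < 2000 nM in this assay, at which 3 of the 3 values shown sit.

The compounds shown leave open how maximal plasma concentration differs among them, including between phenyl and cyclohexyl on the aromatic nitrogen.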